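This account rests on a few compounds, and the source may have more. Where it says the series, first, only, none or still open, it means among the compounds named here.

Measured so far in a functional assay on HT-29 cells (Homo sapiens) for antiproliferative activity, read by sulforhodamine B assay, with a stated time of 72 h; a lower number here means a stronger inhibitor, a higher number a weaker inhibitor:
compound 1, `Fc1cccc(NC(=S)N/N=C/c2ccc3ccccc3n2)c1`, gives 74700 nM.
compound 2, `Fc1ccccc1NC(=S)N/N=C/c1ccc2ccccc2n1`, gives > 100000 nM, which is a limit of the assay rather than a number.

Compound 1 and compound 2 share one core and differ only in where the fluorine sits on the phenyl ring attached to the amide-type nitrogen. The step of an at least 1.3-fold higher number from compound 1 to compound 2 (0.12 log units; that floor lies within the scatter) is known only as a floor, and that floor lies within the scatter of repeated runs. Compound 2 therefore stands at the weak end of what this assay can report, and its value is only a limit, as shown by the limit of > 100000 nM in this assay, at which 1 of the 2 values shown sits.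

Compound 3, `S=C(N/N=C/c1ccc2ccccc2n1)Nc1ccccc1Br`, has not yet been measured. Compared with compound 2 the change is bromo in place of fluoro on an aromatic carbon. Within the data shown here, the only measured step that bears on it is an at least 1.3-fold higher number from compound 1 to compound 2 (0.12 log units; that floor lies within the scatter), which was no larger than the scatter, and no measured step exchanges fluoro for bromo. There is thus no basis to expect compound 3 to move beyond the scatter in this assay in either direction. Compound 3 is expected to give 100000 nM, within 40000 nM to 250000 nM. The step this estimate means, a number no higher from compound 2 to compound 3 (the limit leaves the size open), is expected to stay within the scatter.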

Compound 3, half-maximal inhibitory concentration: > 100000 nM
Compound 3: no number, only a limit; the forecaster's own chance of this, stated with the estimate: 60%; the middle value lies on the limit itself.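

Compound 3 gives only a limit in this assay, and so does compound 2, so a second group at this place, 2-bromophenyl alongside 2-fluorophenyl, ends at the top of the range the assay can report. Among these compounds, the steps that involve two limits cannot be read, so the data cannot say whether bromo and fluoro differ here, only that neither brings a number into the readable range. The one readable comparison is an at least 1.3-fold higher number from compound 1 to compound 3 (0.12 log units; that floor lies within the scatter), so even this floor does not separate 2-bromophenyl from 3-fluorophenyl, and the weak end of the assay now holds most of the series: the limit of > 100000 nM in this assay, at which 2 of the 3 values shown sit.

The compounds shown leave open whether anything at this place on the phenyl ring can bring a readable value, for instance an amine or a methoxy group in place of the halogen. They also leave open how bromo behaves at the place held by fluoro in compound 1, which a 3-bromophenyl group would test, and whether the position of the group matters at all beyond the scatter.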